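A Cyclopropyl in Place of a Larger Group on Compound 2

The source may hold more compounds than are shown below. What is called first, only, known or untested is meant among the compounds shown, and "the series" means these compounds.

Of the compounds shown here, three have been measured in an ADME assay on microsomes from liver (Mus musculus) for metabolic stability; a higher number here means faster removal of the compound, a lower number slower removal. Compound 1 (`CCOc1cc2[nH]c(Cc3nn(CC(=O)N4CCOCC4)c(=O)c4ccccc34)nc2cc1Cl`) gives 817 mL/min/kg as its clearance. Compound 2 (`O=C(Cc1nn(CC(=O)N2CCOCC2)c(=O)c2ccccc12)Nc1ccc(OC(F)(F)F)c(Cl)c1`) gives 11900 mL/min/kg and so holds the higher of the two actual numbers, with a gap to compound 1 that lies beyond the usual scatter. Compound 3 (`O=C(O)Cn1nc(Cc2nc3cc(Cl)c(OCC(F)F)cc3[nH]2)c2ccccc2c1=O`) returns only a limit (< 56.7 mL/min/kg).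

The next compound, compound 4 (`O=C(Cc1nn(C2CC2)c(=O)c2ccccc12)Nc1ccc(OC(F)(F)F)c(Cl)c1`), keeps the rest of compound 2 and changes one place. Cyclopropyl stands in place of ((morpholin-4-yl)carbonyl)methyl on an aromatic nitrogen (cyclopropyl in place of ((morpholin-4-yl)carbonyl)methyl on an aromatic nitrogen). Among the measured compounds shown here, no two measured compounds differ in only one place, so this assay offers no measured step as a guide to this change. The expectation therefore starts from compound 2 at 11900 mL/min/kg and assumes no shift beyond the scatter, with a slight lean towards a lower number. The expected change is small (a 1.3-fold lower number from compound 2 to compound 4 (0.12 log units; within the scatter)) and the estimate stays wide to reflect how little the data constrain it. For compound 4 the estimated clearance is 9000 mL/min/kg with an expected range from 3000 mL/min/kg to 27000 mL/min/kg when it is measured.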

Compound 4, clearance: 2300 mL/min/kg
For compound 4 the middle estimate is 3.9-fold (0.59 log units) above the measured one; measured number below the stated range.
By their numbers in this assay, from the lowest: compound 1; then compound 4; then compound 2. At a limit, below all of these: compound 3.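

In this assay, the group on this aromatic nitrogen proves able to move the read-out on its own: cyclopropyl in place of ((morpholin-4-yl)carbonyl)methyl gives a 5.2-fold lower number from compound 2 to compound 4 (0.71 log units; beyond the scatter). Among the compounds shown here, this is the first step between two measured compounds that differ in one place, and it lies beyond the scatter, so this position cannot be treated as neutral for clearance. The change takes out one six-membered non-aromatic ring, a double bond outside aromatic rings and both hydrogen-bond acceptors of the group that leaves, but no measurement shown here connects any of these to the lower number.

A single step cannot separate the removal of the morpholine ring from the removal of the carbonyl or from the arrival of the three-membered ring of carbon. Going by these compounds, it also remains open how a plain methyl, a longer alkyl chain or a piperidine amide on the same nitrogen would stand in this assay with the rest of compound 2 kept the same.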